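A few compounds are considered here, and "the series" means these few. Any claim that something is new, unique, unknown or untested is made for them only; others in the source may bear on it.

Measured compounds and their values in a functional assay on CHO-K1 cells for agonist activity at Glucose-dependent insulinotropic receptor (Homo sapiens), read by a luciferase reporter, with a stated time of 5 h; on this read-out higher numbers stand for an effect only at larger amounts of compound and lower numbers for an effect already at smaller amounts:
- Compound 1, `CC(C)(C)OC(=O)N1CCC(Oc2cccc3c2ccn3-c2ccc(S(C)(=O)=O)cc2)CC1`, gives 631 nM
- Compound 2, `CC(C)OC(=O)N1CCC(Oc2cccc3c2CCN3c2ccc(S(C)(=O)=O)cc2F)CC1`, gives 1000 nM
- Compound 3, `COC(=O)N1CCC(Oc2ncnc3c2CCN3c2ccc(S(C)(=O)=O)cc2F)CC1`, gives 316 nM

All three share a carbamate on a piperidine that is linked through an oxygen to a fused core carrying a methylsulfonylphenyl group; they differ in the core itself, in a fluorine on that phenyl ring, and in the alkyl part of the carbamate. Compound 3 has the lowest of the three numbers. Its gap to compound 1 lies within the usual scatter, so the two cannot be ranked against each other; its gap to compound 2 lies beyond the scatter, so compound 3 does act at smaller amounts than compound 2.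

Compound 4, `CCCCOC(=O)N1CCC(Oc2ncnc3c2CCN3c2ccc(S(C)(=O)=O)cc2F)CC1`, is built on the core of compound 3, with one change: propyl in place of hydrogen on a saturated chain carbon bound to an oxygen next to a carbonyl group. Going by the values given here, no pair among the measured compounds isolates this kind of change, since compounds 1 and 2 also differ from compound 3 in their cores. Compounds 1 and 2 carry larger alkyl groups on the carbamate and give numbers no lower than compound 3, which suggests that growing the alkyl part does not by itself push the number down. The step of a 1.6-fold higher number from compound 3 to compound 4 (0.20 log units; within the scatter) is therefore expected to be small, if anything toward a slightly higher number. Compound 4 is estimated at 500 nM, with a likely range from 150 nM to 2000 nM.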

Compound 4, half-maximal effective concentration: 50.1 nM
The estimate for compound 4 lay 10-fold (1.00 log units) above the measured number; the measured number lies below the stated range.
By their numbers in this assay, from the lowest: compound 4; then compounds 3, 1 and 2 (each within the scatter of the next, the first and the last beyond it).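

Going by these compounds alone, the change from methoxycarbonyl to butoxycarbonyl is the first single change in this set, and in this assay it gives a 6.3-fold lower number from compound 3 to compound 4 (0.80 log units; beyond the scatter). This shows that the position responds to the size of the carbamate's alkyl group: with the shared core and the fluorine-bearing phenyl ring unchanged, propyl in place of hydrogen on a saturated chain carbon bound to an oxygen next to a carbonyl group moves the number beyond the scatter, toward an effect at smaller amounts. The compounds with other cores could not show this, as their differences lie in more than one place, and nothing available here accounts for the step.

On these data alone, a single step gives no trend, so it remains open whether ethyl would give a number between those of this pair and whether a longer chain such as hexyl would lower the number further or raise it again. Also open, as far as these compounds go, are a chain ending in an amine or a carboxylic acid at this position and whether the butyl gain carries over to the other cores.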